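The source may report more compounds than this note shows. Statements on the series, on what has been measured and on what is new or still open speak of the compounds shown alone.

Measured compounds:
Compound 1 `CCc1ccc(S(=O)(=O)N2CCC(N3CCC(C)CC3)CC2)cc1` gives > 5000 nM in an ADME assay on HCT-116 cells (Homo sapiens) for cytotoxicity, read by CellTiter-Glo, with a stated time of 72 h (on this read-out lower numbers stand for stronger inhibition and higher numbers for weaker inhibition), a value that is a limit of the assay.
Compound 2 `Cc1noc(C)c1S(=O)(=O)N1CCC(N2CCC(C)CC2)CC1` gives > 10000 nM in this assay, also a limit.
Compound 3 `COc1cccc(S(=O)(=O)N2CCC(N3CCC(C)CC3)CC2)c1` gives > 5000 nM, again a limit.

In this assay compound 1 stands only at a limit, and the two other values shown are limits as well. The three sulfonyl substituents give steps that the limits leave unreadable: a step that the two limits leave unreadable from compound 1 to compound 2, a step that the two limits leave unreadable from compound 1 to compound 3 and a step that the two limits leave unreadable from compound 2 to compound 3. Two of the three values sit at the limit of > 5000 nM in this assay, at which 2 of the 3 values shown sit, one at the limit of > 10000 nM in this assay, at which 1 of the 3 values shown sits.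

Compound 4 `CC1CCN(C2CCN(S(=O)(=O)c3ccc(-c4ccc(Cl)cc4)cc3)CC2)CC1` differs from compound 1 in one place: 4-chlorophenyl in place of ethyl on an aromatic carbon. Among the compounds with values here, none of the measured steps changes a group on an aromatic carbon of this kind, so none bears directly on it; they show only that varying the group on the sulfonyl sulfur left every compound at a limit. With no readable step to build on, compound 4 is expected to stay near the region of those limits, so the expected step from compound 1 is a step that the limit leaves unreadable from compound 1 to compound 4, with wide uncertainty. Compound 4 is therefore estimated at 6000 nM, in a range from 1500 nM to 25000 nM, and it may well again be reported only as a limit.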

Compound 4, half-maximal inhibitory concentration: > 5000 nM
Compound 4 ended at the assay's limit; the forecaster's own chance of this, stated with the estimate: 55%; the middle value is on the limit's open side.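

Within the data shown here, compound 4 gives > 5000 nM in this assay, again a limit of the assay, so its comparison with compound 1 cannot be read as a step and no new step follows. The compounds shown leave open the actual inhibitory concentration of all four in this assay, and so whether 4-chlorophenyl in place of ethyl changes it at all.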